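A few compounds are considered here, and "the series" means these few. Any claim that something is new, unique, unknown or untested is made for them only; others in the source may bear on it.

Working notes on the cytotoxicity series.

Going by the values given here, compound 2 `COc1ccc(F)cc1CNCCCNc1ccnc2cc(Cc3ccc(C#N)cc3)ccc12` gives 6050 nM in an ADME assay on HepG2 cells (Homo sapiens) for cytotoxicity, read by luminescence, CellTiter-Glo and ATP content, with a stated time of 72 h (on this read-out higher numbers stand for an effect only at larger amounts of compound and lower numbers for an effect already at smaller amounts), and holds the highest number of the two measured so far; the nearest is compound 1 `COc1ccc(F)cc1CNCCCNc1ccnc2cc(CCc3ccccc3)ccc12`, which in this assay gives 4240 nM, and the gap between the two lies within the scatter. Compound 3 `COc1ccc(F)cc1CNCCCNc1ccnc2cc(-c3ccc(C(C)(C)C)cc3)ccc12` is not yet measured. It differs from compound 2 by 4-(tert-butyl)phenyl in place of 4-cyanobenzyl on an aromatic carbon. Among the compounds with values here, only one measured step touches this position: a 1.4-fold higher number from compound 1 to compound 2 (0.15 log units; within the scatter), a swap of one pendant group for another at the same aromatic carbon, which moved the number by an amount inside the scatter. Within the data shown here, the step to compound 3 exchanges a saturated chain linker for a direct aryl attachment and removes the nitrile, a larger change than the one measured, but no measured pair informs on it. The expectation is therefore a step of a 1.1-fold lower number from compound 2 to compound 3 (0.04 log units; within the scatter), with no direction beyond the scatter. For compound 3 the estimated value in this assay is 5500 nM, range 2000 nM to 15000 nM.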

Compound 3, half-maximal effective concentration: 620 nM
For compound 3 the middle estimate is 8.9-fold (0.95 log units) above the measured one; the whole stated range lies above it.
By their numbers in this assay, from the lowest: compound 3; then compounds 1 and 2 (each within the scatter of the next).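

In this assay this aromatic carbon proves sensitive to the group it carries, with a 9.8-fold lower number from compound 2 to compound 3 (0.99 log units; beyond the scatter) and a 6.8-fold lower number from compound 1 to compound 3 (0.83 log units; beyond the scatter) on bringing in 4-(tert-butyl)phenyl, while the earlier swap gave only a 1.4-fold higher number from compound 1 to compound 2 (0.15 log units; within the scatter) and so had not shown this. The change joins two differences, an aromatic ring bound directly to the core in place of a saturated chain and the arrival of the tert-butyl group, and these compounds cannot separate them. Nothing at hand explains the lower number of compound 3.

On these data alone, whether the direct attachment or the tert-butyl group carries the step stays open, and an unsubstituted phenyl on the same carbon would tell them apart. Also open, as far as these compounds go, is how a directly bound phenyl bearing an amine or a carboxylic acid in place of tert-butyl would read.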